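This account rests on a few compounds, and the source may have more. Where it says the series, first, only, none or still open, it means among the compounds named here.

Measured so far:
compound 1 `Fc1ccc2nc(NCCCCN3CCN(c4cccc(Cl)c4Cl)CC3)nc(NCc3ccco3)c2c1` — 95.5%
compound 2 `Cc1cccc(N2CCN(CCCCNc3nc(NCc4ccco4)c4cc(F)ccc4n3)CC2)c1C` — 93.4%

Compound 1 gives the highest of the two numbers in a functional assay on DU-145 cells (Homo sapiens) for cytotoxicity, read by MTT assay, with a stated time of 2 days, tested at 10 uM; a lower number here means less inhibition, a higher number more inhibition at the concentration tested (going by the name of the read-out); the nearest is compound 2, with a number 2.1 percentage points lower from compound 1 to compound 2 (within the scatter), so the two stand within the scatter. Compound 3 `Clc1cccc(N2CCN(CCCCNc3nc(NCc4ccco4)c4ccccc4n3)CC2)c1Cl` is not yet measured in this assay. It differs from compound 1 by hydrogen in place of fluoro on an aromatic carbon. Among the measured compounds shown here, no measured step bears directly on this change; the only step, between compound 1 and compound 2, concerns a different place and stays within the scatter. With no evidence for a shift, compound 3 is expected to remain near compound 1, a step of a number 4.5 percentage points lower from compound 1 to compound 3 (within the scatter) being estimated, giving an expected value of 91% in this assay, within 75% to 98%.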

Compound 3, a percentage reported as inhibition, at one concentration (the size of the read-out at that concentration, not a potency): 94.3%
Compound 3: the middle estimate sits 3.3 percentage points below what was measured, within the range that was stated.
By their numbers in this assay, from the lowest: compounds 2, 3 and 1 (each within the scatter of the next).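

In this assay, among the compounds shown here, hydrogen in place of fluoro on this aromatic carbon gives a number 1.2 percentage points lower from compound 1 to compound 3 (within the scatter), the first direct reading at this position. The fluoro is therefore not required for a high number at the single concentration tested. No measurement on hand accounts for this result.

On these data alone, whether a methoxy group or an amine on the same aromatic carbon would move the number remains open. A single-concentration reading also leaves open any difference in potency between compound 1 and compound 3.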